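The compounds below may be only part of what the source reports. "The series", "measured", "known", "first", "only" and "open" are said of these compounds alone.

Measured in a functional assay on DU-145 cells (Homo sapiens) for inhibition, read by trypan blue exclusion, with a stated time of 72 h; a lower number here means a stronger inhibitor, a higher number a weaker inhibitor:
- compound 1 `CCn1c(=O)c(S(=O)(=O)c2ccc(F)cc2F)cc2cnc(Nc3ccc4[nH]ccc4c3)nc21`: 750 nM
- compound 2 `O=c1c(S(=O)(=O)c2ccc(F)cc2F)cc2cnc(Nc3ccc4[nH]ccc4c3)nc2n1CC1CCCC1`: 10000 nM

Compound 2 holds the higher of the two numbers, which makes it the weaker inhibitor of the pair. Compound 3 `O=c1c(S(=O)(=O)c2ccc(F)cc2F)cc2cnc(Nc3ccc4[nH]ccc4c3)nc2n1C1CCCCC1` has not yet been measured. It carries cyclohexyl in place of cyclopentylmethyl on an aromatic nitrogen.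

Among the measured compounds shown here, only one measured step bears on this change, a 13-fold higher number from compound 1 to compound 2 (1.12 log units; beyond the scatter). That step, at the same nitrogen, put cyclopentyl in place of methyl on the saturated chain carbon, and it was large. Compound 3 keeps a carbon ring on that nitrogen but has no chain carbon. A single step is thin evidence, so a partial move back towards compound 1 is expected in this assay, smaller than the measured step. The estimated change is a 3.3-fold lower number from compound 2 to compound 3 (0.52 log units; beyond the scatter). For compound 3 the expected value is 3000 nM, with an estimated range of 800 nM to 12000 nM.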

Compound 3, half-maximal inhibitory concentration: 10000 nM
Compound 3: middle estimate off by 3.3-fold (0.52 log units), on the low side, and the stated range covers the measured number.
By their numbers in this assay, from the lowest: compound 1; then compounds 2 and 3 (each within the scatter of the next).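

In this assay, cyclohexyl in place of cyclopentylmethyl on the aromatic nitrogen gives no change at the digits printed from compound 2 to compound 3 (within the scatter), so moving the carbon ring directly onto that nitrogen recovers nothing of what compound 1 shows. Cyclohexyl in place of ethyl gives a 13-fold higher number from compound 1 to compound 3 (1.12 log units; beyond the scatter), a step that matches the one seen with cyclopentylmethyl, so among these compounds both six-carbon groups stand well apart from ethyl, whether or not a chain carbon links the ring to the nitrogen. Nothing given here explains this result.

The compounds shown hold only ethyl and these two six-carbon groups at this position, so they leave open at what size of group the number begins to rise. Going by these compounds, how a cyclopropyl group or a short chain ending in an amine would read on this nitrogen also remains open.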